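Adding a Methylene Spacer to an Oxane Amide

The source may report more compounds than this note shows. Statements on the series, on what has been measured and on what is new or still open speak of the compounds shown alone.

Three amides sharing one core have been measured in an assay on HEK293 cells for negative allosteric modulation of metabotropic glutamate receptor 5 (Homo sapiens), read by FLIPR, with a stated time of 1 h; a lower number here means a stronger inhibitor, a higher number a weaker inhibitor. Compound 1, `O=C(C1CCCC1)N1CCc2nc(C#Cc3ccccc3)sc2C1`, carries a cyclopentyl group on its carbonyl carbon, and in this assay compound 1 gives > 10000 nM, which is a limit of the assay rather than a number. Compound 2, `CC1CCC(C(=O)N2CCc3nc(C#Cc4ccccc4)sc3C2)CC1`, carries 4-methylcyclohexyl instead, and in this assay compound 2 gives > 10000 nM, again a limit. Compound 3, `O=C(C1CCOCC1)N1CCc2nc(C#Cc3ccccc3)sc2C1`, carries oxan-4-yl, and in this assay compound 3 gives > 10000 nM, also a limit. The steps a step that the two limits leave unreadable from compound 1 to compound 2, a step that the two limits leave unreadable from compound 1 to compound 3 and a step that the two limits leave unreadable from compound 2 to compound 3 therefore cannot be read, as the limit of > 10000 nM in this assay, at which 3 of the 3 values shown sit, records.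

Compound 4, `O=C(CC1CCOCC1)N1CCc2nc(C#Cc3ccccc3)sc2C1`, differs from compound 3 by (oxan-4-yl)methyl in place of oxan-4-yl on a carbonyl carbon. All three measured steps change the group on the carbonyl carbon, and none of them gave a readable shift, so for compound 4 the expected step is a step that the limit leaves unreadable from compound 3 to compound 4, nothing beyond the scatter. Compound 4 is estimated to give 15000 nM, in a range from 4000 nM to 60000 nM, most likely reported again only as a limit.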

Compound 4, half-maximal inhibitory concentration: > 10000 nM
Compound 4 was reported as a limit; the forecaster's own chance of this, stated with the estimate: 75%; the middle value lies beyond the limit too.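

Within the data shown here, no step from compound 4 to compound 1, compound 2 or compound 3 can be read in this assay, because each result is only a limit and not a number: the limit of > 10000 nM in this assay, at which 4 of the 4 values shown sit.

The compounds shown leave open how these four groups on the carbonyl carbon rank against one another, and which group, if any, would give a measurable value.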